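A few compounds are considered here, and "the series" means these few. Any claim that something is new, unique, unknown or untested is made for them only; others in the source may bear on it.

Measured compounds:
compound 1 `CCOC(=O)C1=C(N/C=N/c2ccccn2)Nc2[nH]nc(C)c2C1c1ccc(N(C)C)cc1` – 37300 nM
compound 2 `CCOC(=O)C1=C(N/N=C(/Cl)C#N)Nc2[nH]nc(C)c2C1c1ccc(N(C)C)cc1` – 23200 nM
compound 3 `CCOC(=O)C1=C(N/N=C(/C(C)=O)C(=O)OCC)Nc2[nH]nc(C)c2C1c1ccc(N(C)C)cc1` – > 100000 nM

In a functional assay on MCF7 cells (Homo sapiens) for inhibition, read by MTT assay, with a stated time of 48 h (on this read-out lower numbers stand for stronger inhibition and higher numbers for weaker inhibition), compound 1 gives 37300 nM and compound 2 gives 23200 nM. The step of a 1.6-fold lower number from compound 1 to compound 2 (0.21 log units; within the scatter). The value of compound 3 in this assay is a limit of the assay and not a number; it sits at the limit of > 100000 nM in this assay, at which 1 of the 3 values shown sits. Compound 3 therefore stands at the weak end of the three: an at least 2.6-fold higher number from compound 1 to compound 3 (0.42 log units; beyond the scatter), and an at least 4.3-fold higher number from compound 2 to compound 3 (0.63 log units; beyond the scatter), both beyond the scatter.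

Compound 4 `CCOC(=O)C(=NNC1=C(C(=O)OCC)C(c2ccc(N(C)C)cc2)c2c(C)n[nH]c2N1)C(=O)OCC` differs from compound 3 by a group of 12 heavy atoms (7 carbon, 1 nitrogen, 4 oxygen; no ring) in place of a group of 10 heavy atoms (6 carbon, 1 nitrogen, 3 oxygen; no ring), on an amine nitrogen. Going by the values given here, no measured step alters this group in the same manner; the two steps that lead into compound 3 exchange it for groups of a quite different kind, so they bear on compound 4 only by placing its parent at the limit. The change itself is small in count and type, and no movement beyond the scatter is expected. For compound 4 the step is expected to be a step that the limit leaves unreadable from compound 3 to compound 4. Compound 4 is thus expected near 150000 nM, between 60000 nM and 400000 nM, most likely again reported only as a limit in this assay.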

Compound 4, half-maximal inhibitory concentration: 89800 nM
Beside the measured number, compound 4's estimate is 1.7-fold (0.22 log units) above it; low and high end bracket the measured number.
By their numbers in this assay, from the lowest: compounds 2 and 1 (each within the scatter of the next); then compound 4. At a limit, above all of these: compound 3.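

In this assay, a group of 12 heavy atoms on the amine nitrogen gives this position a measured number for one of the larger groups with no ring, and that number lies on the weak side of both smaller groups: a 3.9-fold higher number from compound 2 to compound 4 (0.59 log units; beyond the scatter), and a 2.4-fold higher number from compound 1 to compound 4 (0.38 log units; beyond the scatter). Compound 3 stands at a limit of the assay and not at a number: the limit of > 100000 nM in this assay, at which 1 of the 4 values shown sits. The exchange of its group of 10 heavy atoms for the group of 12 heavy atoms can be given only as an at least 1.1-fold lower number from compound 3 to compound 4 (0.04 log units; that floor lies within the scatter), so the size of that step cannot be read.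

Heavy-atom count and group type change together across compounds 1 to 4, so the data do not separate the two. A plain acetyl group, a primary amine or a carboxylic acid on the same amine nitrogen would bear on that question.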